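Swapping an alkyl ether for a chlorophenyl ether

The source may report more compounds than this note shows. Statements on the series, on what has been measured and on what is new or still open speak of the compounds shown alone.

Measured compounds:
Compound 1 `Cc1cc(Sc2ccncc2)c(S(C)(=O)=O)cc1C(=O)N=C(N)N`: 13 nM
Compound 2 `Cc1cc(OC(C)C)c(S(C)(=O)=O)cc1C(=O)N=C(N)N`: 19 nM

Both compounds were tested in a functional assay for inhibition of sodium/hydrogen exchanger (Oryctolagus cuniculus); on this read-out lower numbers stand for stronger inhibition and higher numbers for weaker inhibition. Compound 2 gives the higher of the two numbers, yet the measured step between the two is a 1.5-fold higher number from compound 1 to compound 2 (0.16 log units; within the scatter), so the two cannot be told apart with confidence.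

Compound 3 `Cc1cc(Oc2ccccc2Cl)c(S(C)(=O)=O)cc1C(=O)N=C(N)N` is not yet measured. Compared with compound 2 the change is 2-chlorophenyl in place of isopropyl on an oxygen on an aromatic ring. Going by the values given here, the only measured step, from compound 1 to compound 2, replaces a (pyridin-4-yl)sulfanyl group with isopropoxy and stays within the scatter; it shows that a ring-bearing substituent and a small alkyl one at this position of the shared core give similar numbers, but it does not test a 2-chlorophenyl group on an oxygen. Among the compounds with values here, with no direct precedent, the step from compound 2 to compound 3 is expected to be small, a 1.3-fold lower number from compound 2 to compound 3 (0.10 log units; within the scatter), in no firm direction. Compound 3 is therefore estimated at 15 nM, with a likely range of 5 nM to 45 nM.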

Compound 3, half-maximal inhibitory concentration: 14 nM
Beside the measured number, compound 3's estimate is 1.1-fold (0.03 log units) above it; the range from low to high includes it.
By their numbers in this assay, from the lowest: compounds 1, 3 and 2 (each within the scatter of the next).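

In this assay, placing 2-chlorophenyl on the oxygen in place of isopropyl gives a 1.4-fold lower number from compound 2 to compound 3 (0.13 log units; within the scatter) and so leaves the two groups indistinguishable, even though the incoming group brings a ring and 7 heavy atoms against 3. Replacing (pyridin-4-yl)sulfanyl with 2-chlorophenoxy gives a 1.1-fold higher number from compound 1 to compound 3 (0.03 log units; within the scatter) and shows that two different ring-bearing groups also cannot be told apart here, so all three compounds sit within the scatter of one another. No available evidence explains this similarity. Still open, from the compounds shown here alone, is whether a chain on this oxygen longer than isopropyl, or an amine or a carboxylic acid carried on it, would give a number clearly different from these. Also open, going by these compounds, is what a plain phenyl group, without the chlorine, would give.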